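This account rests on a few compounds, and the source may have more. Where it says the series, first, only, none or still open, it means among the compounds named here.

Of the compounds shown here, three built on one shared core have been measured in an assay on HEK293 cells for displacement of a labelled ligand from metabotropic glutamate receptor 5 (Rattus norvegicus); a lower number here means a stronger inhibitor, a higher number a weaker inhibitor. Compound 1 `O=C(Nc1cc(-c2ccccc2)nn1-c1ccccc1)c1ccccc1` gives 4180 nM. Compound 2 `O=C(Nc1cc(-c2ccccc2)nn1-c1ccccc1)c1cccc(C(F)(F)F)c1` gives 1650 nM, and compound 3 `COc1ccc(C(=O)Nc2cc(-c3ccccc3)nn2-c2ccccc2)cc1` gives 420 nM. Compound 3 therefore stands with the lowest number of the three: the step of a 10-fold lower number from compound 1 to compound 3 (1.00 log units; beyond the scatter) and the step of a 3.9-fold lower number from compound 2 to compound 3 (0.59 log units; beyond the scatter) both lie beyond the scatter, while a 2.5-fold lower number from compound 1 to compound 2 (0.40 log units; beyond the scatter) is a smaller move in the same direction. Compound 4 `O=C(Nc1cc(-c2ccccc2)nn1-c1ccccc1)c1ccc(OC(F)(F)F)cc1` differs from compound 3 by trifluoromethyl in place of methyl on an oxygen on an aromatic ring. Within the data shown here, no measured step matches this change exactly; the nearest hints are the modest moves from compound 1 to compound 2 and from compound 1 to compound 3, which each added a group to compound 1 and each lowered the number. The change here swaps one group for another rather than adding one, so the step of a 1.8-fold higher number from compound 3 to compound 4 (0.25 log units; within the scatter) expected in this assay is small, with a somewhat higher number judged more likely than a lower one. Compound 4 is accordingly estimated at 750 nM, within a range from 250 nM to 2200 nM.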

Compound 4, inhibition constant: 265 nM
Estimate against measurement, compound 4: 2.8-fold (0.45 log units) above, within the range that was stated.
By their numbers in this assay, from the lowest: compounds 4 and 3 (each within the scatter of the next); then compound 2; then compound 1.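

In this assay, a 1.6-fold lower number from compound 3 to compound 4 (0.20 log units; within the scatter) means that trifluoromethyl in place of methyl on the oxygen cannot be told apart from no change at all. The large step, a 16-fold lower number from compound 1 to compound 4 (1.20 log units; beyond the scatter), shows that the lower number seen with methoxy in place of hydrogen on this aromatic carbon is kept with trifluoromethoxy, so this place accepts both groups. Nothing at hand explains why the two groups read alike here.

On these data alone, whether the oxygen itself matters stays open: a plain methyl or a chlorine on the same aromatic carbon would test that, and a longer chain such as ethoxy would show whether the number holds as the group grows. An amine or a carboxylic acid there would show whether the low number survives a group of a very different kind.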